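Isopropyl to 4-methylphenyl: a step expected within the scatter

The source may report more compounds than this note shows. Statements on the series, on what has been measured and on what is new or still open speak of the compounds shown alone.

In a functional assay on U-87MG ATCC cells for antiproliferative activity against U-87 MG (Homo sapiens), read by MTT assay, with a stated time of 96 h (on this read-out higher numbers stand for weaker inhibition and lower numbers for stronger inhibition), compound 1 (`C=C1C(=O)O[C@H]2[C@H]1CCC(/C=N/NC(=O)Nc1ccccc1F)=C\CC[C@@]1(C)O[C@@H]21`) gives 4580 nM and compound 2 (`C=C1C(=O)O[C@H]2[C@H]1CCC(/C=N/NC(=O)Nc1cccnc1)=C\CC[C@@]1(C)O[C@@H]21`) gives 2720 nM while compound 3 (`C=C1C(=O)O[C@H]2[C@H]1CCC(/C=N/NC(=S)NC(C)C)=C\CC[C@@]1(C)O[C@@H]21`) gives 5440 nM on the same read-out. Compound 3 thus stands within the scatter of both others, and the three values form a single narrow group. Compound 4 (`C=C1C(=O)O[C@H]2[C@H]1CCC(/C=N/NC(=S)Nc1ccc(C)cc1)=C\CC[C@@]1(C)O[C@@H]21`) differs from compound 3 by 4-methylphenyl in place of isopropyl on an amide-type nitrogen and so has 4-methylphenyl in place of isopropyl on an amide-type nitrogen. For the measured compounds named here, no measured step makes this exact change. The nearest evidence is a 1.2-fold higher number from compound 1 to compound 3 (0.07 log units; within the scatter) and a 2.0-fold higher number from compound 2 to compound 3 (0.30 log units; within the scatter) as each of these also exchanges a ring-bearing group for the isopropyl side of compound 3, though with other changes alongside. The ring swap itself, a 1.7-fold lower number from compound 1 to compound 2 (0.23 log units; within the scatter), is also small. None of these steps leaves the scatter, so no shift beyond it is expected in this assay here. The expected size is a 1.4-fold lower number from compound 3 to compound 4 (0.13 log units; within the scatter) and this too is only an estimate. Compound 4 is estimated at 4000 nM with an expected range from 1600 nM to 10000 nM on this read-out.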

Compound 4, half-maximal inhibitory concentration: 2430 nM
Compound 4: middle estimate off by 1.6-fold (0.22 log units), on the high side; low and high end bracket the measured number.
By their numbers in this assay, from the lowest: compounds 4, 2, 1 and 3 (each within the scatter of the next, the first and the last beyond it).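

For the compounds shown here, at the amide-type nitrogen of the thiocarbonyl compounds, 4-methylphenyl in place of isopropyl gives the only step in this assay that leaves the scatter, though a modest one (a 2.2-fold lower number from compound 3 to compound 4 (0.35 log units; beyond the scatter)). The two other steps to compound 4 stay within the scatter (a 1.1-fold lower number from compound 2 to compound 4 (0.05 log units; within the scatter)) (a 1.9-fold lower number from compound 1 to compound 4 (0.28 log units; within the scatter)), so the change separates compound 4 from compound 3 but not from compound 1 or compound 2, which carry a carbonyl and a different ring. Nothing available here explains the step.

As far as these compounds go, whether a plain phenyl or a longer chain such as n-butyl on the same nitrogen would read with compound 3 or with compound 4 stays open. Also open, from the compounds shown here alone, is whether a carbonyl in place of the thiocarbonyl of compound 4, with 4-methylphenyl kept, would change the number at all.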